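A few compounds are considered here, and "the series" means these few. Any claim that something is new, unique, unknown or untested is made for them only; others in the source may bear on it.

Compound 1 `O=C(c1cccnc1)N1CCC(C(=O)N2N=CCC2c2ccccc2)CC1`: 2.6
Compound 2 `CN1CCC(C2CC=NN2C(=O)C(C)(C)C)CC1`: 1.4
Compound 3 `CC(C)(C)C(=O)N1N=CCC1C1CCCC1`: 6.7

Of the compounds shown here, three have so far been measured in a physicochemical assay for lipophilicity, read by HPLC, measured as chromatographic lipophilicity, at pH 7.4; a lower number here means a more polar compound, a higher number a more lipophilic compound. Among them, compound 1 stands second highest. Its nearest neighbour is compound 2, whose value of 1.4 lies well below it, a gap beyond the scatter. Furthest away is compound 3, whose value of 6.7 lies far above that of compound 1, again beyond the scatter. No two of these compounds differ in only one place, so no single step between measured compounds can be read from the three numbers.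

The next compound, compound 4 `O=C(c1cc[nH]n1)N1CCC(C(=O)N2N=CCC2c2ccccc2)CC1`, has not yet been measured. It differs from compound 1 in one place:

1H-pyrazol-3-yl in place of pyridin-3-yl on a carbonyl carbon

The group that leaves carries no hydrogen-bond donor, while the group that enters carries one hydrogen-bond donor and one hydrogen-bond acceptor. For the measured compounds named here, on that basis a step towards the lower end is expected in this assay, of moderate size and likely beyond the scatter, although no measured pair in this set confirms such a step. The estimated step is a number 0.60 log units lower from compound 1 to compound 4 (beyond the scatter). Compound 4 is therefore expected to give about 2, with a plausible range from 1.4 to 2.6.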

Compound 4, distribution coefficient: 2.4
For compound 4 the middle estimate is 0.40 log units below the measured one; the range from low to high includes it.
By their numbers in this assay, from the lowest: compound 2; then compounds 4 and 1 (each within the scatter of the next); then compound 3.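

For the compounds shown here, this is the first step in the set that can be read at a single place, and in this assay it gives a number 0.20 log units lower from compound 1 to compound 4 (within the scatter) when 1H-pyrazol-3-yl takes the place of pyridin-3-yl on a carbonyl carbon. Going by these compounds alone, at this position, then, a six-membered aromatic ring with no hydrogen-bond donor and a five-membered aromatic ring with one hydrogen-bond donor give numbers that this assay does not separate, so compound 1 and compound 4 stand together on this scale, while the earlier compounds, which differ in more than one place, could show nothing about this position. Nothing at hand gives a reason for this outcome.

A single pair cannot show whether the position would stay as undemanding with a group of a different kind on this carbonyl carbon, such as a plain phenyl ring, a piperidine carrying a free amine, or a ring bearing a carboxylic acid. Nor does it show whether the same exchange would read alike if the rest of the core of compound 1 were changed.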